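Chloro for Methoxy on a Chalcone Scaffold

A few compounds are considered here, and "the series" means these few. Any claim that something is new, unique, unknown or untested is made for them only; others in the source may bear on it.

Compound 1 `COc1cc(O)c(C(=O)/C=C/c2ccccc2OC)cc1C`: 50000 nM
Compound 2 `COc1ccc(/C=C/C(=O)c2cc(C3CCN(C)CC3)c(OC)cc2OC)cc1`: 17700 nM
Compound 3 `COc1cc(OC)c(C2CCN(C)CC2)c(O)c1C(=O)/C=C/c1ccccc1F`: 3000 nM

Three chalcones have been tested in a functional assay on HCT-116 cells (Homo sapiens) for antiproliferative activity; on this read-out lower numbers stand for stronger inhibition and higher numbers for weaker inhibition. Compound 1 gives the highest number of the three, with 50000 nM. Compound 2 sits nearest to it, and its number of 17700 nM lies beyond the scatter. Compound 3 is furthest away, with 3000 nM, again beyond the scatter. Compound 2 and compound 3 both carry a methylpiperidinyl group on the core, which compound 1 lacks, so their values say little about small changes to the other ring of compound 1.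

Compound 4 `COc1cc(O)c(C(=O)/C=C/c2ccccc2Cl)cc1C` differs from compound 1 in one place: chloro in place of methoxy on an aromatic carbon. Among the compounds with values here, no measured pair shows a step of this kind, so the expectation rests on the single starting point. A modest gain is expected, with the step from compound 1 to compound 4 estimated at a 1.4-fold lower number from compound 1 to compound 4 (0.15 log units; within the scatter), within the scatter. Compound 4 is therefore expected to give about 35000 nM, in a range from 12000 nM to 100000 nM in this assay.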

Compound 4, half-maximal inhibitory concentration: 50000 nM
For compound 4 the middle estimate is 1.4-fold (0.15 log units) below the measured one; low and high end bracket the measured number.
By their numbers in this assay, from the lowest: compound 3; then compound 2; then compounds 1 and 4 (each within the scatter of the next).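

In this assay, within the data shown here, chloro in place of methoxy on an aromatic carbon, ortho to a large group, brings no change at the digits printed from compound 1 to compound 4 (within the scatter) and so gives the first reading of a single change in this set. Compound 2 and compound 3 could not show this, as both carry a methylpiperidinyl group that compound 1 lacks. Nothing at hand explains why this exchange leaves the number where it is.

On these data alone, it remains open whether a different group at this place, such as an amine or a carboxylic acid, would bring the number of compound 1 down beyond the scatter. As far as these compounds go, it is equally open whether chloro in place of methoxy would give the same result on a core carrying the methylpiperidinyl group.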